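This account rests on a few compounds, and the source may have more. Where it says the series, first, only, none or still open, it means among the compounds named here.

Measured so far in an assay on CHO-K1 cells for displacement of a labelled ligand from adenosine receptor A1 (Homo sapiens), read by scintillation counting, with a stated time of 60 min; on this read-out higher numbers stand for weaker inhibition and lower numbers for stronger inhibition:
Compound 1 `N#Cc1ccc(/C=N/Nc2nc(N)c3ncn([C@@H]4O[C@H](CO)[C@@H](O)[C@H]4O)c3n2)cc1` gives 4.1 nM.
Compound 2 `CCCCc1nc(/C=N/Nc2nc(N)c3ncn([C@@H]4O[C@H](CO)[C@@H](O)[C@H]4O)c3n2)c(Cl)[nH]1` gives 12 nM.
Compound 3 `Nc1nc(N/N=C/c2ccc(-n3ccnc3)cc2)nc2c1ncn2[C@@H]1O[C@H](CO)[C@@H](O)[C@H]1O` gives only a limit of the assay, > 10000 nM.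

Within the data shown here, of the two actual numbers, compound 2 has the higher one; the step of a 2.9-fold higher number from compound 1 to compound 2 (0.47 log units; beyond the scatter) separates it from the only other number. For compound 3 the result is a limit, not a number, which is the case noted as the limit of > 10000 nM in this assay, at which 1 of the 3 values shown sits.

Compound 4 `Nc1nc(N/N=C/c2ccc(C(F)(F)F)cc2)nc2c1ncn2[C@@H]1O[C@H](CO)[C@@H](O)[C@H]1O` has not yet been measured. It differs from compound 2 in one place: 4-(trifluoromethyl)phenyl in place of 2-butyl-5-chloro-1H-imidazol-4-yl on a carbon with a double bond to nitrogen.

Among the measured compounds shown here, two measured steps bear on this change. The step of a 2.9-fold higher number from compound 1 to compound 2 (0.47 log units; beyond the scatter) shows that swapping a 4-cyanophenyl for the 2-butyl-5-chloro-1H-imidazol-4-yl raised the number modestly, so returning to a phenyl ring carrying a small group might lower it by about as much. The step of an at least 830-fold higher number from compound 2 to compound 3 (2.92 log units; beyond the scatter) shows that a phenyl ring carrying a 1H-imidazol-1-yl instead lost almost all binding, so a phenyl ring alone is no guarantee. Since trifluoromethyl is a small group closer in kind to cyano than to an imidazole, a modest step downward is expected, a 2.4-fold lower number from compound 2 to compound 4 (0.38 log units; beyond the scatter). The expected value for compound 4 in this assay is 5 nM, with a range from 1.5 nM to 20 nM.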

Compound 4, inhibition constant: 37 nM
Estimate against measurement, compound 4: 7.4-fold (0.87 log units) below; the measured number lies above the stated range.
By their numbers in this assay, from the lowest: compound 1; then compound 2; then compound 4. At a limit, above all of these: compound 3.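

Putting 4-(trifluoromethyl)phenyl in place of 2-butyl-5-chloro-1H-imidazol-4-yl in this assay gives a 3.1-fold higher number from compound 2 to compound 4 (0.49 log units; beyond the scatter), so a phenyl ring does not decide the outcome alone: compound 1 also carries one and has the lower number. With the phenyl ring kept, the group on the aromatic carbon makes a clear difference, as trifluoromethyl in place of cyano gives a 9.0-fold higher number from compound 1 to compound 4 (0.96 log units; beyond the scatter), while trifluoromethyl in place of 1H-imidazol-1-yl gives an at least 270-fold lower number from compound 3 to compound 4 (2.43 log units; beyond the scatter). Compound 3 carries a limit, not a number: the limit of > 10000 nM in this assay, at which 1 of the 4 values shown sits.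

As far as these compounds go, it remains open whether an amine, a carboxylic acid or a methoxy group on that aromatic carbon would fall nearer compound 1 or compound 3. Also open, from the compounds shown here alone, is whether a shorter chain than butyl, or hydrogen in place of chlorine, would change the number for compound 2.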